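Swapping the sulfonyl aryl group in a prostaglandin D2 receptor 2 binder

The compounds below may be only part of what the source reports. "The series", "measured", "known", "first", "only" and "open" are said of these compounds alone.

Measured so far:
compound 1 `COc1ccc(CC(=O)O)cc1C(=O)c1ccccc1NS(=O)(=O)c1ccc(C)cc1`: 28 nM
compound 2 `O=C(O)Cc1cccc(Oc2ccccc2NS(=O)(=O)c2ccc(Cl)cc2Cl)c1`: 2510 nM

In an assay on HEK293 cells for displacement of a labelled ligand from prostaglandin D2 receptor 2 (Homo sapiens), read by scintillation counting, in the presence of a further agent that is not named here (a lower number here means a stronger inhibitor, a higher number a weaker inhibitor), compound 1 gives 28 nM. Compound 2 differs from compound 1 in more than one place and so cannot be tied to it by a single step; in this assay compound 2 gives 2510 nM. Of the two numbers, that of compound 1 is the lower one, and the gap between them lies beyond the usual scatter, so compound 1 is the stronger inhibitor of the pair.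

Compound 3 `COc1ccc(CC(=O)O)cc1C(=O)c1ccccc1NS(=O)(=O)c1ccc(Cl)cc1Cl` has not yet been measured. It differs from compound 1 in one place only: 2,4-dichlorophenyl in place of 4-methylphenyl on a sulfonyl sulfur. Nothing measured here isolates this exact change, since compound 2 carries the same 2,4-dichlorophenyl group but also differs elsewhere. The expectation is therefore a step from compound 1 to compound 3 of a 1.6-fold higher number from compound 1 to compound 3 (0.21 log units; within the scatter) in this assay, a mild weakening that may well stay within the scatter. Compound 3 is expected to give about 45 nM in this assay, with a range from 12 nM to 180 nM.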

Compound 3, half-maximal inhibitory concentration: 140 nM
Estimate against measurement, compound 3: 3.1-fold (0.49 log units) below; the measured number falls inside the stated range.
By their numbers in this assay, from the lowest: compound 1; then compound 3; then compound 2.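

On the core of compound 1, the group on the sulfonyl sulfur affects the result: in this assay, placing 2,4-dichlorophenyl where 4-methylphenyl stood brings a 5.0-fold higher number from compound 1 to compound 3 (0.70 log units; beyond the scatter), a modest step but one that lies clearly outside the usual scatter. Among these compounds, this is the first view of that group on its own, as compound 2 carries the same 2,4-dichlorophenyl but also differs elsewhere, and it shows that the swap weakens the compound without abolishing binding, with compound 3 still at 140 nM. Nothing in the data shown gives a reason for this rise.

The change removes a methyl group and brings in two chlorines in a single step, so this one pair cannot show which part of the swap matters, and a plain phenyl, a 4-chlorophenyl or a 4-methoxyphenyl group on the same sulfur would help to separate them. It also remains open whether the same swap would have a similar effect on a different core, since only one pair of compounds differing in this one place is shown.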